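Moving the Chloro and Trifluoromethyl Groups on a Diaryl Urea

The source may hold more compounds than are shown below. What is called first, only, known or untested is meant among the compounds shown, and "the series" means these compounds.

Measured compounds:
compound 1, `CC(NC(=O)/C=C/Oc1ccc(NC(=O)Nc2cc(C(F)(F)F)ccc2Cl)cc1)c1ccccc1`, 11900 nM
compound 2, `C/C(=C\C(=O)NC(C)c1ccccc1)c1ccc(NC(=O)Nc2ccc(Cl)c(C(F)(F)F)c2)cc1`, > 50000 nM
compound 3, `CNC(=O)/C=C/c1ccc(NC(=O)Nc2ccc(Cl)c(C(F)(F)F)c2)cc1`, 20400 nM

Of the compounds shown here, three sharing a diaryl urea have been tested in a functional assay on HepG2 cells (Homo sapiens) for inhibition, read by MTT assay, with a stated time of 120 h; a lower number here means a stronger inhibitor, a higher number a weaker inhibitor. Compound 1 gives 11900 nM. Compound 3 gives 20400 nM; the two numbers for compound 1 and compound 3 lie within the scatter of each other, so neither can be called the more potent. For compound 2 the assay reports only a limit, > 50000 nM, which is no number (the limit of > 50000 nM in this assay, at which 1 of the 3 values shown sits).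

Compound 4, `CC(NC(=O)/C=C/Oc1ccc(NC(=O)Nc2ccc(Cl)c(C(F)(F)F)c2)cc1)c1ccccc1`, has not yet been measured in this assay. It differs from compound 1 in one place: 4-chloro-3-(trifluoromethyl)phenyl in place of 2-chloro-5-(trifluoromethyl)phenyl on an amide-type nitrogen. No pair of measured compounds differs by just this change, so its effect cannot be read from a shown step. Compound 3 does carry the entering group. Because compound 3 gives 20400 nM, the step of a 1.3-fold higher number from compound 1 to compound 4 (0.13 log units; within the scatter) is expected to be small, probably none beyond the scatter. Compound 4 is therefore expected to give about 16000 nM, within a range of 5000 nM to 50000 nM.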

Compound 4, half-maximal inhibitory concentration: 14100 nM
The estimate for compound 4 lay 1.1-fold (0.05 log units) above the measured number, and the stated range covers the measured number.
By their numbers in this assay, from the lowest: compounds 1, 4 and 3 (each within the scatter of the next). At a limit, above all of these: compound 2.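

Exchanging 2-chloro-5-(trifluoromethyl)phenyl for 4-chloro-3-(trifluoromethyl)phenyl on an amide-type nitrogen gives, in this assay, a 1.2-fold higher number from compound 1 to compound 4 (0.07 log units; within the scatter). The earlier compounds shown here offered no pair differing in this one place; now the two arrangements of the same atoms can be compared directly on the core of compound 1, and this assay does not tell them apart. Nothing measured here bears on why the two arrangements read alike.

As far as these compounds go, whether this exchange stays as small on other cores, such as that of compound 3, remains open. Also open, from the compounds shown here alone, is how the number would respond if a nitrile or a methoxy group took the place of the chloro group, or if a carboxylic acid or an amine stood on this ring.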